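The source may hold more compounds than are shown below. What is called first, only, known or untested is meant among the compounds shown, and "the series" means these compounds.

Measured so far in a functional assay on B16 cells (Mus musculus) for cytotoxicity, read by MTT assay, with a stated time of 72 h; on this read-out lower numbers stand for stronger inhibition and higher numbers for weaker inhibition:
- compound 1 `COc1cccc(/C=C/C(=O)Nc2cc(C(=O)c3cc(OC)c(OC)c(OC)c3)cc(OC)c2OC)c1`: compound 1 gives 6700 nM
- compound 2 `COc1cc(C(=O)c2cc(OC)c(OC)c(OC)c2)cc(NC(=O)/C=C/c2ccc(F)cc2)c1OC`: compound 2 gives 900 nM

Among the compounds with values here, compound 2 stands at the lowest of these two numbers, with compound 1 the only neighbour. Compound 3 `COc1cc(C(=O)c2cc(OC)c(OC)c(OC)c2)cc(NC(=O)/C=C/c2ccc(C(F)(F)F)cc2)c1OC` differs from compound 2 by trifluoromethyl in place of fluoro on an aromatic carbon. Within the data shown here, the only measured step, a 7.4-fold lower number from compound 1 to compound 2 (0.87 log units; beyond the scatter), exchanged a whole substituted ring and so does not bear directly on this smaller change; no measured step does. A step within the scatter, or a modest weakening, is expected. The expected step is a 1.7-fold higher number from compound 2 to compound 3 (0.22 log units; within the scatter). Compound 3 is therefore estimated at 1500 nM, ranging from 400 nM to 6000 nM.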

Compound 3, half-maximal inhibitory concentration: 3300 nM
Compound 3: the middle estimate sits 2.2-fold (0.34 log units) below what was measured, within the range that was stated.
By their numbers in this assay, from the lowest: compound 2; then compound 3; then compound 1.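

In this assay, the carbon para to a large group proves sensitive to what it carries: trifluoromethyl in place of fluoro gives a 3.7-fold higher number from compound 2 to compound 3 (0.56 log units; beyond the scatter), a weakening beyond the scatter. The 4-(trifluoromethyl)phenyl ring still does better than 3-methoxyphenyl, with a 2.0-fold lower number from compound 1 to compound 3 (0.31 log units; beyond the scatter), so 4-fluorophenyl remains the best of these three rings. Nothing measured here explains why the larger group does worse. Open, from the compounds shown here alone, is how chloro, a nitrile or an amine at this same place would compare with fluoro and trifluoromethyl.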